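The source may report more compounds than this note shows. Statements on the series, on what has been measured and on what is new or still open speak of the compounds shown alone.

Measured compounds in an ADME assay on PBMC cells (Homo sapiens) for cytotoxicity; on this read-out higher numbers stand for lower toxicity in this test and lower numbers for higher toxicity in this test:

- compound 1, `CC(CCNC(=O)c1c(Cl)cncc1Cl)N1CCC(C(Oc2ccncc2)c2ccc(Br)cc2)CC1`: 31200 nM
- compound 2, `CC(CCNC(=O)c1c(Cl)cncc1Cl)N1CCC(C(Oc2ccccc2)c2ccc(C(F)(F)F)cc2)CC1`: 6800 nM
- compound 3, `CCO/N=C(/c1ccc(Br)cc1)C1CCN(C(C)CCN(C)C(=O)c2c(C)cc[n+]([O-])c2C)CC1`: > 182000 nM (a limit of the assay, not a number)

Compound 2 gives the lowest of the two numbers in this assay, so the strongest cytotoxicity among the compounds with a real value; compound 1 sits higher by a gap beyond the scatter. Compound 3 reaches only the limit of > 182000 nM in this assay, at which 1 of the 3 values shown sits, and contributes no number. Going by the values given here, no step between measured compounds is available, so the series gives no measured guide for the change now considered.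

Compound 4, `CC(CCNC(=O)c1c(Cl)cncc1Cl)N1CCC(C(Oc2ccccc2C#N)c2ccc(C(F)(F)F)cc2)CC1`, is not yet measured in this assay. It differs from compound 2 as follows: cyano in place of hydrogen on an aromatic carbon. With no measured step of this kind in the series, the step from compound 2 to compound 4 is expected to be small, likely within the usual scatter, with no direction assumed; the estimated step is a 1.2-fold higher number from compound 2 to compound 4 (0.07 log units; within the scatter). Compound 4 is therefore expected to give about 8000 nM in this assay, with a range from 3000 nM to 25000 nM.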

Compound 4, half-maximal cytotoxic concentration: 17000 nM
Estimate against measurement, compound 4: 2.1-fold (0.33 log units) below, and the stated range covers the measured number.
By their numbers in this assay, from the lowest: compound 2; then compounds 4 and 1 (each within the scatter of the next). At a limit, above all of these: compound 3.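

Phenoxy to 2-cyanophenoxy gives the first measured step at this position in this assay, a 2.5-fold higher number from compound 2 to compound 4 (0.40 log units; beyond the scatter), so cyano in place of hydrogen, ortho to a large group on this six-membered aromatic ring of carbon only, moves the read-out towards lower toxicity in this test. The position therefore accepts a substituent without any rise in cytotoxicity here, at least for this one group on the trifluoromethyl-bearing scaffold of compound 2. Nothing shown accounts for the size or direction of this step.

On these data alone, whether an amine, a carboxylic acid or a methoxy group at the same place would move the read-out the same way remains open. Also open, as far as these compounds go, is whether cyano gives a similar step at other positions on this ring, or with the bromo and pyridine-containing core of compound 1.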